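This account rests on a few compounds, and the source may have more. Where it says the series, first, only, none or still open, it means among the compounds named here.

In a functional assay on L6 cells (Rattus norvegicus) for inhibition (a higher number here means a weaker inhibitor, a lower number a stronger inhibitor), the measured compounds stand as follows:
compound 1 `CC(C)c1c(C(=O)N2CCCC2c2ccccc2)nn(-c2ccc(F)cc2)c1OC[C@@H](O)C[C@@H](O)CC(=O)O` gives 4340 nM;
compound 2 `Cc1ccc(CNC(=O)c2nn(-c3ccc(F)cc3)c(OC[C@@H](O)C[C@@H](O)CC(=O)O)c2C(C)C)cc1` gives 2110 nM;
compound 3 `COc1ccccc1CNC(=O)c1nn(-c2ccc(F)cc2)c(OC[C@@H](O)C[C@@H](O)CC(=O)O)c1C(C)C` gives "not determined" (no result reported), that is, no result is reported.

For the measured compounds named here, compound 2 holds the lowest of the two numbers, and the only measured step, a 2.1-fold lower number from compound 1 to compound 2 (0.31 log units; beyond the scatter), is a modest one that changes the group on the carbonyl carbon. Compound 4 `COc1cccc(CN(C)C(=O)c2nn(-c3ccc(F)cc3)c(OC[C@@H](O)C[C@@H](O)CC(=O)O)c2C(C)C)c1` differs from compound 2 at the same place: (3-methoxybenzyl)(methyl)amino in place of (4-methylbenzyl)amino on a carbonyl carbon. Going by the values given here, that single step is the only guide, and it shows that exchanging the group on the carbonyl carbon moves this assay only modestly. Compound 4 is therefore expected near 2200 nM, within a range of 900 nM to 5500 nM. This estimate means a step of a 1.0-fold higher number from compound 2 to compound 4 (0.02 log units; within the scatter), expected to stay within the scatter.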

Compound 4, half-maximal inhibitory concentration: 9460 nM
Estimate against measurement, compound 4: 4.3-fold (0.63 log units) below; the whole stated range lies below it.
By their numbers in this assay, from the lowest: compound 2; then compound 1; then compound 4.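

In this assay, the group on the carbonyl carbon proves able to move the number further than the earlier step showed: a 4.5-fold higher number from compound 2 to compound 4 (0.65 log units; beyond the scatter), and a 2.2-fold higher number from compound 1 to compound 4 (0.34 log units; beyond the scatter). The (3-methoxybenzyl)(methyl)amino group gives the highest number of the three measured compounds, but this single change swaps the ring substituent and removes the amide hydrogen together, so their contributions cannot be separated. Nothing shown here accounts for the shift. The compounds leave open how a (4-methylbenzyl)(methyl)amino group or a (3-methoxybenzyl)amino group would read, either of which would separate those two changes.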